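The compounds below may be only part of what the source reports. "The series", "measured", "known", "first", "only" and "open" are said of these compounds alone.

Compound 1 `Nc1ncc(-c2cnn(C3CCNCC3)c2)cc1-c1nc2ccc(OCc3ccccc3)cc2o1` gives 6900 nM in an assay on isolated protein for inhibition of G protein-coupled receptor kinase 5 (Homo sapiens), read by TR-FRET, with stated times of 10 min and 1 h; on this read-out higher numbers stand for weaker inhibition and lower numbers for stronger inhibition.
Compound 2 `Nc1ncc(-c2cnn(C3CCNCC3)c2)cc1-c1nc2ccc(Oc3ccccc3)cc2o1` gives 4000 nM in this assay.

Among the measured compounds shown here, only two compounds have been measured, and they differ in one place: a 1.7-fold lower number from compound 1 to compound 2 (0.24 log units; within the scatter). Compound 2 therefore stands within the scatter of compound 1, and neither can be called the stronger inhibitor on these numbers.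

Compound 3 `Nc1ncc(-c2cnn(C3CCNCC3)c2)cc1-c1nc2ccc(-c3ccc4[nH]ncc4c3)cc2o1` is the next step from compound 2. The change is 1H-indazol-5-yl in place of phenoxy on an aromatic carbon. For the measured compounds named here, no measured step covers a change of this kind: the only step seen, from compound 1 to compound 2, swaps one group attached through an oxygen for another and stays within the scatter, so it gives no guide to replacing the phenoxy group with a directly attached bicyclic ring carrying a hydrogen-bond donor. For compound 3 in this assay the expectation is a modest move toward a lower number, a 1.6-fold lower number from compound 2 to compound 3 (0.20 log units; within the scatter), with wide uncertainty. The estimate for compound 3 is 2500 nM, within 400 nM to 15000 nM.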

Compound 3, half-maximal inhibitory concentration: 1140 nM
Beside the measured number, compound 3's estimate is 2.2-fold (0.34 log units) above it; measured number inside the range.
By their numbers in this assay, from the lowest: compound 3; then compounds 2 and 1 (each within the scatter of the next).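

The position responds to the group placed on it in this assay: replacing phenoxy with 1H-indazol-5-yl gives a 3.5-fold lower number from compound 2 to compound 3 (0.55 log units; beyond the scatter), and replacing benzyloxy with the same group gives a 6.1-fold lower number from compound 1 to compound 3 (0.78 log units; beyond the scatter). This change does several things at once, removing the oxygen, adding a five-membered aromatic ring with hetero atoms and bringing in a hydrogen-bond donor that phenoxy lacks, so these steps cannot credit any one of those differences. No accompanying evidence helps to separate them.

The compounds shown leave open whether a plain phenyl ring attached directly to the same carbon, or 1-methyl-1H-indazol-5-yl with a methyl group replacing the ring hydrogen, would give a similar step. They also leave open how an amine or a carboxylic acid at this position would behave.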